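This account rests on a few compounds, and the source may have more. Where it says the series, first, only, none or still open, it means among the compounds named here.

Measured in a functional assay on SNB-75 cells (Homo sapiens) for inhibition; on this read-out lower numbers stand for stronger inhibition of growth and higher numbers for weaker inhibition of growth:
- compound 1 `COc1ccc(-n2cnnc2-c2cc(OC)c(OC)c(OC)c2)cc1`, 2340 nM
- compound 2 `COc1cc(-c2nncn2-c2ccc(N(C)C)cc2)cc(OC)c1OC`, 107 nM
- compound 3 `COc1ccc(-n2cnnc2-c2cc(OC)c(OC)c(OC)c2)cc1O`, 251 nM

Compound 3 at 251 nM has the second highest of the three numbers and lies closer to compound 2 than to compound 1. The unmeasured compound 4 `COc1ccc(-n2cnnc2-c2cc(OC)c(OC)c(OC)c2)cc1F` differs from it by fluoro in place of hydroxy on an aromatic carbon, with fluoro in place of hydroxy on an aromatic carbon, ortho to a methoxy group.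

The measured step bearing most directly on this is a 9.3-fold lower number from compound 1 to compound 3 (0.97 log units; beyond the scatter), which introduced the same hydroxy in place of hydrogen. The other step, a 22-fold lower number from compound 1 to compound 2 (1.34 log units; beyond the scatter), concerns dimethylamino in place of methoxy on a different aromatic carbon and offers little guidance here. Fluoro has not been measured anywhere in this series, so the expectation is loose. Part of the first step is expected to be lost, though not necessarily all of it.

In this assay the expected change is a 2.8-fold higher number from compound 3 to compound 4 (0.45 log units; beyond the scatter), towards a higher number. For compound 4 the estimated value is 700 nM, with an expected range from 200 nM to 2500 nM.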

Compound 4, concentration for 50% growth inhibition: 3020 nM
The estimate for compound 4 lay 4.3-fold (0.63 log units) below the measured number, outside the stated range (above it).
By their numbers in this assay, from the lowest: compound 2; then compound 3; then compounds 1 and 4 (each within the scatter of the next).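

In this assay, fluoro in place of hydroxy ortho to a methoxy group gives a large loss (a 12-fold higher number from compound 3 to compound 4 (1.08 log units; beyond the scatter)), while fluoro in place of hydrogen at the same carbon gives no distinguishable change (a 1.3-fold higher number from compound 1 to compound 4 (0.11 log units; within the scatter)). The gain from hydroxy in place of hydrogen (a 9.3-fold lower number from compound 1 to compound 3 (0.97 log units; beyond the scatter)) is therefore not retained with fluoro, which cannot be told apart from hydrogen here, so at this position the gain is specific to hydroxy among the groups shown. No measured evidence accounts for the difference between hydroxy and fluoro.

As far as these compounds go, whether any other group at this carbon can recover the gain remains open, and an amine or a hydroxymethyl group would be the next informative comparison. Also open, from the compounds shown here alone, is whether hydroxy at this carbon would add to the gain from dimethylamino in place of methoxy (a 22-fold lower number from compound 1 to compound 2 (1.34 log units; beyond the scatter)).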